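Chain Lengthening and Cytotoxicity Limits in THP-1 Cells

This account rests on a few compounds, and the source may have more. Where it says the series, first, only, none or still open, it means among the compounds named here.

Compound 1 `CCCCCCCCCCn1cc(-c2nc3ccccc3cc2CCCC)nn1`; in a functional assay on THP-1 cells (Homo sapiens) for cytotoxicity, read by MTT assay, with a stated time of 24 h (on this read-out higher numbers stand for weaker inhibition and lower numbers for stronger inhibition), compound 1 gives > 100 ug/mL, a limit of the assay rather than a number.
Compound 2 `CCCCCCCCCCn1cc(-c2nc3ccccc3cc2CCC)nn1`; in this assay compound 2 gives > 100 ug/mL, again a limit.
Compound 3 `CCc1cc2ccccc2nc1-c1cn(-c2ccc(F)cc2)nn1`; in this assay compound 3 gives > 100 ug/mL, also a limit.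

All three measured values sit at the limit of > 100 ug/mL in this assay, at which 3 of the 3 values shown sit. Compound 2 and compound 1 differ in one place: methyl in place of hydrogen on a saturated chain carbon, three bonds along the chain from an aromatic carbon. The step that the two limits leave unreadable from compound 2 to compound 1 therefore cannot be read from the two limits. How the core of compound 3 differs from the core of compound 2 is not broken down here.

Compound 4 `CCCc1cc2ccccc2nc1-c1cn(-c2ccc(F)cc2)nn1` has not yet been measured. It differs from compound 3 by methyl in place of hydrogen on a saturated chain carbon, two bonds along the chain from an aromatic carbon. This is the same kind of change as from compound 2 to compound 1, but not the same: there the methyl enters three bonds along the chain from an aromatic carbon, here two bonds along the chain from an aromatic carbon.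

Because compound 3 gives > 100 ug/mL and the earlier change left compound 1 at > 100 ug/mL, the step that the limit leaves unreadable from compound 3 to compound 4 is expected to stay unreadable. Compound 4 is estimated at 150 ug/mL, between 80 ug/mL and 400 ug/mL.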

Compound 4, half-maximal inhibitory concentration: > 100 ug/mL
Compound 4: a limit, no number; the forecaster's own chance of this, stated with the estimate: 85%; the middle value does not contradict the limit.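

Compound 3 and compound 4 both stay at a limit rather than a number in this assay, so no step between them can be read: the limit of > 100 ug/mL in this assay, at which 4 of the 4 values shown sit.

The compounds shown leave open how strongly any of them acts in this assay, and whether methyl in place of hydrogen on the chain changes that at all.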